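A few compounds are considered here, and "the series" means these few. Any claim that something is new, unique, unknown or untested is made for them only; others in the source may bear on it.

Of the compounds shown here, three that share one core have been measured in a functional assay on EKVX cells (Homo sapiens) for inhibition, read by sulforhodamine B assay, with a stated time of 48 h; on this read-out higher numbers stand for weaker inhibition of growth and lower numbers for stronger inhibition of growth. Compound 1 `CC(=O)/C(=C\c1c(-c2ccccc2)[nH]c2ccccc12)S(=O)(=O)c1ccccc1` gives 3300 nM, compound 2 `O=C(/C(=C\c1c(-c2ccccc2)[nH]c2ccccc12)S(=O)(=O)c1ccccc1)c1ccccc1` gives 4600 nM, and compound 3 `COc1ccc2[nH]c(-c3ccccc3)c(/C=C(\C#N)S(=O)(=O)c3ccccc3)c2c1` gives 6900 nM, the highest of the three numbers. Going by the values given here, the only single-change step among them, a 1.4-fold higher number from compound 1 to compound 2 (0.14 log units; within the scatter), is a swap at the carbonyl carbon and says nothing about the aromatic ring. Compound 4 `N#C/C(=C\c1c(-c2ccccc2)[nH]c2ccccc12)S(=O)(=O)c1ccccc1` differs from compound 3 by hydrogen in place of methoxy on an aromatic carbon. Among the compounds with values here, no measured step bears on this change, so for compound 4 the expected step is a 1.2-fold lower number from compound 3 to compound 4 (0.06 log units; within the scatter), nothing beyond the scatter. Compound 4 is therefore estimated at 6000 nM in this assay, with a range from 2500 nM to 14000 nM.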

Compound 4, concentration for 50% growth inhibition: 6200 nM
For compound 4 the middle estimate is 1.0-fold (0.01 log units) below the measured one; the range from low to high includes it.
By their numbers in this assay, from the lowest: compounds 1, 2, 4 and 3 (each within the scatter of the next, the first and the last beyond it).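

The step at this aromatic carbon, hydrogen in place of methoxy, gives a 1.1-fold lower number from compound 3 to compound 4 (0.05 log units; within the scatter), so this assay does not tell these two groups apart. Compound 4 also allows a comparison at the chain carbon that carries the sulfonyl: cyano in place of benzoyl gives a 1.3-fold higher number from compound 2 to compound 4 (0.13 log units; within the scatter), and cyano in place of acetyl gives a 1.9-fold higher number from compound 1 to compound 4 (0.27 log units; within the scatter), so neither swap moves beyond the scatter. Nothing available gives a reason for these results. On these data alone, it remains open whether an amine or a carboxylic acid on this aromatic carbon would give a number beyond the scatter.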